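Moving the Trifluoromethyl Group Around the Phenyl Ring

A few compounds are considered here, and "the series" means these few. Any claim that something is new, unique, unknown or untested is made for them only; others in the source may bear on it.

compound 1 `Oc1ccc(-c2cc(-c3cccc(F)c3)cc(-c3ccc(O)cc3)n2)cc1` — 9290 nM
compound 2 `Oc1ccc(-c2cc(-c3ccccc3C(F)(F)F)cc(-c3ccc(O)cc3)n2)cc1` — > 50000 nM

Of the compounds shown here, two sharing one core have been tested in a functional assay on DU-145 cells (Homo sapiens) for inhibition; a lower number here means a stronger inhibitor, a higher number a weaker inhibitor. Compound 1 gives 9290 nM in this assay. Compound 2 reaches only a limit, > 50000 nM, in this assay. Compound 2 therefore stands at the weak end of what the numbers shown can tell, as the limit of > 50000 nM in this assay, at which 1 of the 2 values shown sits, records. For the measured compounds named here, the single measured step, an at least 5.3-fold higher number from compound 1 to compound 2 (0.73 log units; beyond the scatter), is the only one that bears on the new compound, and it was at least modest in size. Compound 3 `Oc1ccc(-c2cc(-c3ccc(C(F)(F)F)cc3)cc(-c3ccc(O)cc3)n2)cc1` is the next to be measured; it differs from compound 2 in that (4-(trifluoromethyl)phenyl in place of 2-(trifluoromethyl)phenyl on an aromatic carbon). The move of the trifluoromethyl group within the same phenyl ring partly reverses the change that separated compound 1 from compound 2, so some recovery of inhibition is expected, though one step is a thin basis. The step is estimated as an at least 2.5-fold lower number from compound 2 to compound 3 (0.39 log units; beyond the scatter). Compound 3 is expected to give about 20000 nM, within 6000 nM to 50000 nM, in this assay.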

Compound 3, half-maximal inhibitory concentration: > 50000 nM
Compound 3: only a limit was reported; the forecaster's own chance of this, stated with the estimate: 35%; at least 2.5-fold (0.39 log units) between middle value and limit.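

Compound 2 and compound 3 both stop at a limit of the assay rather than at a number: the limit of > 50000 nM in this assay, at which 2 of the 3 values shown sit.

From the compounds shown here alone, the steps that end on these two limits at both sides cannot be read, so the order of 2-(trifluoromethyl)phenyl and 4-(trifluoromethyl)phenyl at this position stays unknown. The loss of inhibition is nevertheless not confined to 2-(trifluoromethyl)phenyl: 4-(trifluoromethyl)phenyl in place of 3-fluorophenyl also gives an at least 5.3-fold higher number from compound 1 to compound 3 (0.73 log units; beyond the scatter).

Open, going by these compounds, is whether 3-(trifluoromethyl)phenyl, which carries its group where compound 1 carries its fluorine, would give a readable number in this assay or would also end at a limit. Equally open, on these data alone, is how a plain phenyl, or a phenyl carrying an amine or a carboxylic acid, would behave at this position opposite the ring nitrogen, and whether any of these would give a stronger inhibitor than compound 1.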